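The source may report more compounds than this note shows. Statements on the series, on what has been measured and on what is new or still open speak of the compounds shown alone.

Compound 1 `C#CCSc1nc(Nc2cccc(C(F)(F)F)c2)c(C#N)c(-c2ccccc2)n1`: in a functional assay on MCF7 cells (Homo sapiens) for inhibition, read by MTT assay, with a stated time of 72 h (a higher number here means a weaker inhibitor, a lower number a stronger inhibitor), compound 1 gives only a limit, > 128000 nM.
Compound 2 `N#Cc1c(Nc2ccccc2Cl)nc(SCc2cn(Cc3ccccc3Cl)nn2)nc1-c1ccccc1`: in this assay compound 2 gives 1950 nM.

Of the two measured results, compound 2 holds the only actual number; the other result is a limit, as shown in the limit of > 128000 nM in this assay, at which 1 of the 2 values shown sits. Compound 3 `N#Cc1c(Nc2ccccc2F)nc(SCc2cn(Cc3ccccc3Cl)nn2)nc1-c1ccccc1` differs from compound 2 by fluoro in place of chloro on an aromatic carbon. Going by the values given here, no measured step of this kind is available, so the expectation rests on the change alone, one halogen swapped for another at the same place; the step from compound 2 to compound 3 is expected to be small, within or just beyond the usual scatter, leaning if anything toward weaker inhibition, a 1.5-fold higher number from compound 2 to compound 3 (0.19 log units; within the scatter). Compound 3 is therefore estimated at 3000 nM, with a likely range from 1000 nM to 10000 nM.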

Compound 3, half-maximal inhibitory concentration: 8060 nM
Compound 3: middle estimate off by 2.7-fold (0.43 log units), on the low side; measured number inside the range.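

Replacing 2-chlorophenyl with 2-fluorophenyl in this assay gives a 4.1-fold higher number from compound 2 to compound 3 (0.62 log units; beyond the scatter) and so is a modest but real loss of inhibition. Going by these compounds alone, this is the first readable step at this position, and it shows that the choice of halogen on this aromatic carbon matters, with chloro ahead of fluoro in this pair. Nothing measured here explains the step.

The compounds shown leave open whether bromo, a methyl group or an amine at the same place would match chloro or surpass it.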